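Phenyl versus methoxyphenoxy on the shared core

A few compounds are considered here, and "the series" means these few. Any claim that something is new, unique, unknown or untested is made for them only; others in the source may bear on it.

Working notes on the series built on the core of compound 1 `Cc1ccccc1-n1nc(C)c2c1NC(=O)[C@H](C)S[C@@H]2c1ccc(-c2cc3ccccc3o2)cc1`. In an assay on isolated protein for agonist activity at Bile acid receptor (Homo sapiens), read by AlphaScreen, with a stated time of 30 min (on this read-out lower numbers stand for smaller maximal responses and higher numbers for larger maximal responses), compound 1 gives 17%. Compound 2 `Cc1ccccc1-n1nc(C)c2c1NC(=O)[C@H](C)S[C@@H]2c1ccc(Oc2ccccc2)cc1` gives 118% in this assay, and compound 3 `COc1cccc(Oc2ccc([C@H]3S[C@@H](C)C(=O)Nc4c3c(C)nn4-c3ccccc3C)cc2)c1` gives 120%. Compound 3 and compound 2 sit together within the scatter, the step of a number 2 percentage points higher from compound 2 to compound 3 (within the scatter) being small, while both stand far above compound 1: a number 101 percentage points higher from compound 1 to compound 2 (beyond the scatter) and a number 103 percentage points higher from compound 1 to compound 3 (beyond the scatter).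

Compound 4 `Cc1ccccc1-n1nc(C)c2c1NC(=O)[C@H](C)S[C@@H]2c1ccc(-c2ccccc2)cc1` is not yet measured. Its change from compound 3 is phenyl in place of 3-methoxyphenoxy on an aromatic carbon. Among the measured compounds shown here, no measured step swaps a phenoxy-type group for a plain phenyl, so the closest guide is the contrast between compound 1, which carries a ring joined directly to the core and gives 17%, and compound 3 with 120%. Compound 4 also carries a ring joined directly to the core, so a drop in this assay is expected, but its size is uncertain; the estimated step of a number 60 percentage points lower from compound 3 to compound 4 (beyond the scatter) is taken as intermediate. Compound 4 is therefore expected at 60%, within 15% to 115%.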

Compound 4, largest response reached (reported as efficacy), in percent of the reference or control that the assay uses: 24%
Compound 4: the middle estimate sits 36 percentage points above what was measured, within the range that was stated.
By their numbers in this assay, from the lowest: compounds 1 and 4 (each within the scatter of the next); then compounds 2 and 3 (each within the scatter of the next).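

Phenyl on this aromatic carbon, para to a large group, does not keep the response seen with the phenoxy-type groups: the step is a number 96 percentage points lower from compound 3 to compound 4 (beyond the scatter) and, against the unsubstituted phenoxy, a number 94 percentage points lower from compound 2 to compound 4 (beyond the scatter). Phenyl and 1-benzofuran-2-yl read alike, with a number 7 percentage points higher from compound 1 to compound 4 (within the scatter), so among these compounds the low response in this assay does not depend on a fused ring system; both directly joined rings stand apart from the two oxygen-linked groups. No measurement available here accounts for this separation.

The compounds shown leave open whether the oxygen itself is needed, or whether a link through an amine nitrogen or a methylene carbon would serve equally. On these data alone, how far the outer ring tolerates substitution also stays open, for example a carboxylic acid in place of methoxy.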